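The source may hold more compounds than are shown below. What is called first, only, known or untested is meant among the compounds shown, and "the series" means these compounds.

Measured so far in an ADME assay on microsomes from liver (Rattus norvegicus) for metabolic stability, read by LC-MS, tested at 0.5 uM; a higher number here means that the compound lasts longer, a lower number that the compound disappears faster:
Compound 1, `Cc1nc(C)c([C@H](OC(C)(C)C)C(=O)O)c(N2CCC(C)(C)CC2)c1-c1ccc(OCCc2ccc(F)c(F)c2)cc1`, gives 0.85 h.
Compound 2, `Cc1ccc(CCOc2ccc(-c3c(C)nc(C)c([C@H](OC(C)(C)C)C(=O)O)c3N3CCC(C)(C)CC3)cc2)s1`, gives only a limit of the assay, > 2 h.

Compound 2 therefore stands at the upper edge of what this assay reports (the limit of > 2 h in this assay, at which 1 of the 2 values shown sits). Among the measured compounds shown here, the one step measured, an at least 2.3-fold higher number from compound 1 to compound 2 (0.37 log units; beyond the scatter), was at least modest and upward, with 5-methylthiophen-2-yl in place of 3,4-difluorophenyl on a saturated chain carbon, two bonds along the chain from an oxygen on an aromatic ring.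

Compound 3, `Cc1nc(C)c([C@H](OC(C)(C)C)C(=O)O)c(N2CCC(C)(C)CC2)c1-c1ccc(OCCc2ccccn2)cc1`, is not yet measured. It differs from compound 2 by pyridin-2-yl in place of 5-methylthiophen-2-yl on a saturated chain carbon, two bonds along the chain from an oxygen on an aromatic ring. For the measured compounds named here, the only step that touches this position exchanged a different pair of groups, so it bears on the new change loosely. Because compound 2 is known only as a limit (the limit of > 2 h in this assay, at which 1 of the 2 values shown sits), a moderate fall could still leave compound 3 inside the reported range, and no direction is firmly indicated.

Compound 3 is expected to give about 1.5 h in this assay, estimated between 0.7 h and 3 h. The expected step from compound 2 to compound 3 is an at least 1.3-fold lower number from compound 2 to compound 3 (0.12 log units; that floor lies within the scatter).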

Compound 3, half-life: 1.02 h
For compound 3 the middle estimate is 1.5-fold (0.17 log units) above the measured one; measured number inside the range.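

In this assay, the exchange at this position gives an at least 1.9-fold lower number from compound 2 to compound 3 (0.29 log units; that floor lies within the scatter), so the floor alone does not establish a real difference between 5-methylthiophen-2-yl and pyridin-2-yl. Compound 2 remains known only as a limit: the limit of > 2 h in this assay, at which 1 of the 3 values shown sits.

Among the compounds shown here, the new comparison with the 3,4-difluorophenyl group gives a 1.2-fold higher number from compound 1 to compound 3 (0.08 log units; within the scatter), so pyridin-2-yl and 3,4-difluorophenyl are not separated here, and 5-methylthiophen-2-yl is the only group of the three with a step printed as beyond the scatter.

The compounds shown leave open whether that step depends on the sulfur-containing ring or on its methyl group, which an unsubstituted thiophen-2-yl group would help to separate. They also leave open how pyridin-3-yl, pyridin-4-yl or a plain phenyl group would behave on the same chain.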